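From an Oxazole Ring to Piperidine in Alpha-1D Agonists

This account rests on a few compounds, and the source may have more. Where it says the series, first, only, none or still open, it means among the compounds named here.

Of the compounds shown here, three have so far been tested in a functional assay for activation of Alpha-1D adrenergic receptor (Homo sapiens) (a higher number here means that more compound is needed for the effect, a lower number that less compound is needed), and each of them has given only a limit rather than a number. Compound 1 `c1ccc(-c2ccccc2OCc2c[nH]cn2)cc1` stands at a limit of < 100000 nM. Compound 2 `c1ccc(-c2cnco2)c(NCC2=NCCN2)c1` stands at a limit of < 5020 nM. Compound 3 `c1ccc(-c2cnco2)c(NCc2c[nH]cn2)c1` stands at a limit of < 252 nM. Where compound 3 lies is therefore known only as a limit, and the step that the two limits leave unreadable from compound 2 to compound 3 cannot be given a size because the limit of < 5020 nM in this assay, at which 1 of the 3 values shown sits, and the limit of < 252 nM in this assay, at which 1 of the 3 values shown sits, bound both of its ends.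

Compound 4 `c1ccc(N2CCCCC2)c(NCc2c[nH]cn2)c1` differs from compound 3 in one place: piperidin-1-yl in place of 1,3-oxazol-5-yl on an aromatic carbon. Among the measured compounds shown here, no measured step covers this exchange. For the measured compounds named here, the one measured step, a step that the two limits leave unreadable from compound 2 to compound 3, concerns a different ring and is itself unreadable, and compound 1 shares no single-point change with either compound 3 or compound 4. Nothing in the measurements so far fixes the direction or the size of the change from compound 3 to compound 4 in this assay, and the estimate must rest on the limit at which compound 3 stands.

Compound 4 is therefore expected to give roughly 1000 nM, with a range from 100 nM to 10000 nM. The step of an at least 3.9-fold higher number from compound 3 to compound 4 (0.59 log units; beyond the scatter) that this estimate implies is expected to be uncertain in both size and direction.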

Compound 4, half-maximal effective concentration: < 5020 nM
Compound 4: a limit, no number (the forecaster's own chance of this, stated with the estimate: 35%); the middle value lies beyond the limit too.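

Compound 3 and compound 4 each give only a limit and not a number, and the step between them cannot be read. The compounds shown leave open whether piperidin-1-yl in place of 1,3-oxazol-5-yl raises, lowers or leaves unchanged the concentration needed in this assay.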